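A few compounds are considered here, and "the series" means these few. Any claim that something is new, unique, unknown or untested is made for them only; others in the source may bear on it.

Compound 1 `Cc1cc(CO)nc(NNC(=O)Nc2cc(Cl)nc(Cl)c2)c1` gives 31 nM in a functional assay on CHO cells for antagonist activity at sphingosine 1-phosphate receptor 2 (Homo sapiens), read by scintillation counting and GTPgammaS binding, with a stated time of 4 h, in the presence of a further agent that is not named here; a lower number here means a stronger inhibitor, a higher number a weaker inhibitor.
Compound 2 `Cc1cc(CNC(=O)Nc2cc(OCC(O)CO)nc(C(F)(F)F)c2)nnc1-c1cn(C)nc1C(F)(F)F` gives > 11000 nM in this assay, a limit of the assay and not a number.
Compound 3 `Cc1cc(CNC(=O)Nc2cc(OCCO)nc(C(F)(F)F)c2)nnc1-c1cn(C)nc1C(F)(F)F` gives 704 nM in this assay.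

Compound 3 thus stands highest of the two numbers shown; compound 1 lies well below it, and compound 2 is known only as the limit of > 11000 nM in this assay, at which 1 of the 3 values shown sits. For the measured compounds named here, the single measured step, an at least 15-fold lower number from compound 2 to compound 3 (1.19 log units; beyond the scatter), concerns the chain on the ring oxygen, not the ring itself.

Compound 4 `Cc1cc(CNC(=O)Nc2cc(C(F)(F)F)nc(OCCO)c2C)nnc1-c1cn(C)nc1C(F)(F)F` is not yet measured. It differs from compound 3 by methyl in place of hydrogen on an aromatic carbon. Going by the values given here, no measured step touches a substituent on this ring carbon, so the step from compound 2 to compound 3 gives no direct guidance. Compound 4 is therefore expected to remain close to compound 3, with a 1.0-fold lower number from compound 3 to compound 4 (0.00 log units; within the scatter) within the scatter. The estimate for compound 4 is 700 nM, between 200 nM and 2500 nM.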

Compound 4, half-maximal inhibitory concentration: 169 nM
Compound 4: middle estimate off by 4.1-fold (0.62 log units), on the high side; the measured number lies below the stated range.
By their numbers in this assay, from the lowest: compound 1; then compound 4; then compound 3. At a limit, above all of these: compound 2.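

Methyl in place of hydrogen on this aromatic carbon, ortho to a 2-hydroxyethoxy group and para to a trifluoromethyl group, gives a 4.2-fold lower number from compound 3 to compound 4 (0.62 log units; beyond the scatter) in this assay. For the compounds shown here, this ring carbon, which no earlier step touched, is therefore a place where a small substitution moves the number beyond the scatter, and here towards a stronger inhibitor. Nothing measured here accounts for this change. On these data alone, whether an ethyl group, a chlorine or a methoxy group on this carbon would act like methyl remains open. So does whether the methyl step would carry over to other chains on the ring oxygen.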